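The source may report more compounds than this note shows. Statements on the series, on what has been measured and on what is new or still open speak of the compounds shown alone.

Measured compounds:
- compound 1, `CCNC(=O)c1noc(-c2cc(C(C)C)c(O)cc2O)c1-c1cc(CNC)no1`: 164 nM
- compound 2, `CCNC(=O)c1noc(-c2cc(C(C)C)c(O)cc2O)c1-c1cc(C(=O)O)no1`: no result

Compound 1 carries a methylaminomethyl-bearing five-membered ring on the shared core and in a functional assay on HCT-116 cells (Homo sapiens) for inhibition (on this read-out lower numbers stand for stronger inhibition and higher numbers for weaker inhibition), compound 1 gives 164 nM. Compound 2 differs from it in that ring's substituent, and for compound 2 the entry reads "not determined" (no result reported), so compound 2 stands on no number at all; no comparison with compound 1 can be drawn from it.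

Compound 3, `CCNC(=O)c1noc(-c2cc(C(C)C)c(O)cc2O)c1-c1cnn(C(C)C)c1`, is not yet measured. It changes the same position: 1-isopropyl-1H-pyrazol-4-yl in place of 3-carboxy-1,2-oxazol-5-yl on an aromatic carbon. For the measured compounds named here, no measured step for this change exists, and with compound 2 lacking a result neither the direction nor the size of the step into compound 3 can be anchored. Going by the values given here, the only foothold is compound 1 at 164 nM in this assay, where a different group occupies the same position.

Compound 3 is therefore expected to land near 180 nM, with a range of 45 nM to 700 nM, the wide span reflecting the absence of any measured step for the exchange.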

Compound 3, half-maximal inhibitory concentration: 21 nM
Compound 3: the middle estimate sits 8.6-fold (0.93 log units) above what was measured, outside the stated range (below it).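

In this assay, for the compounds shown here, the group on this aromatic carbon of the shared core clearly affects the read-out: replacing 3-((methylamino)methyl)-1,2-oxazol-5-yl with 1-isopropyl-1H-pyrazol-4-yl gives a 7.8-fold lower number from compound 1 to compound 3 (0.89 log units; beyond the scatter) as the first readable step at this position. Compound 3 carries no amine in this group, so the methylaminomethyl substituent of compound 1 is not needed to reach a lower number in this pair. The exchange alters both the ring and its substituent, so the step cannot be assigned to either change alone, and no measurement at hand accounts for it.

Compound 2 has no number, so the steps that involve it cannot be read, and the carboxylic acid on the 1,2-oxazole remains unplaced relative to the other two groups. Also open, from the compounds shown here alone, is how much of the step belongs to the isopropyl group, since a pyrazole bearing methyl or a longer chain on its nitrogen, or a pyrazole carrying the methylaminomethyl group, would be needed to separate the contribution of the ring from that of its substituent.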